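A fluoro for a methoxy at the assay's upper limit

A few compounds are considered here, and "the series" means these few. Any claim that something is new, unique, unknown or untested is made for them only; others in the source may bear on it.

Compound 1 `Cc1cnc(Nc2ccc(C(C)C)cc2)nc1Nc1nc2ccccc2s1` gives > 50000 nM in a functional assay on MDA-MB-231 cells (Homo sapiens) for antiproliferative activity, read by MTT assay, with a stated time of 48 h (a higher number here means a weaker inhibitor, a lower number a stronger inhibitor), which is a limit of the assay.
Compound 2 `NS(=O)(=O)c1ccc(Nc2ncc(F)c(Nc3nc4ccccc4s3)n2)cc1` gives 22600 nM in this assay.
Compound 3 `COc1cccc(Nc2ncc(C)c(Nc3nc4ccccc4s3)n2)c1` gives > 50000 nM in this assay, again a limit of the assay.

Three compounds share a core. Two of the three values sit at the limit of > 50000 nM in this assay, at which 2 of the 3 values shown sit, and only compound 2 returns a number. Compound 3 therefore stands at the top of what this assay can report, with no readable number of its own. Within the data shown here, the single one-place step, a step that the two limits leave unreadable from compound 1 to compound 3, stays unreadable because the limit of > 50000 nM in this assay, at which 2 of the 3 values shown sit, covers both of its ends. Among the measured compounds shown here, compound 2 differs from compound 3 in more than one place, so its value shows only that a number is reachable.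

Compound 4 `Cc1cnc(Nc2cccc(F)c2)nc1Nc1nc2ccccc2s1` differs from compound 3 by fluoro in place of methoxy on an aromatic carbon. For the measured compounds named here, no measured step bears on this change, and the one step that touches this ring gives no size. Compound 4 is therefore expected to stay near the limit, at an estimated 50000 nM, with a range from 15000 nM to 100000 nM. The expected step of a number no higher from compound 3 to compound 4 (the limit leaves the size open) is none beyond the scatter, and a limit again is the likelier outcome.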

Compound 4, half-maximal inhibitory concentration: > 50000 nM
Compound 4 gave a limit, no number; the forecaster's own chance of this, stated with the estimate: 65%; the middle value sits exactly at the limit.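

Compound 4 gives > 50000 nM in this assay, which is a limit of the assay. The steps among compound 1, compound 3 and compound 4 therefore cannot be read: the limit of > 50000 nM in this assay, at which 3 of the 4 values shown sit.

The compounds shown leave open what fluoro in place of methoxy does to the value in this assay.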